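Benzyl-to-hydroxy step on a flavone-piperazine cytotoxicity series

The source may report more compounds than this note shows. Statements on the series, on what has been measured and on what is new or still open speak of the compounds shown alone.

Measured so far:
- compound 1, `CCOC(=O)COc1cc(-c2cc(=O)c3c(O)cc(OCC(=O)N4CCN(Cc5ccc(OC)cc5)CC4)cc3o2)ccc1OC`: "not determined" (no result reported)
- compound 2, `CCOC(=O)COc1cc(-c2cc(=O)c3c(O)cc(OCC(=O)N4CCN(Cc5ccc(OC)cc5OC)CC4)cc3o2)ccc1OC`: 5600 nM
- compound 3, `CCOC(=O)COc1cc(-c2cc(=O)c3c(O)cc(OCC(=O)N4CCN(Cc5ccc(OCc6ccccc6)c(OC)c5OC)CC4)cc3o2)ccc1OC`: 10000 nM

In an ADME assay on MRC5 cells (Homo sapiens) for cytotoxicity (a lower number here means a stronger inhibitor, a higher number a weaker inhibitor), compound 3 gives 10000 nM, the highest of the two numbers, while compound 2 gives 5600 nM, a gap that lies within the scatter, so no order can be read between them. Compound 1 has no number in this assay.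

Compound 4, `CCOC(=O)COc1cc(-c2cc(=O)c3c(O)cc(OCC(=O)N4CCN(Cc5ccc(O)c(OC)c5OC)CC4)cc3o2)ccc1OC`, differs from compound 3 by hydrogen in place of benzyl on an oxygen on an aromatic ring. Among the compounds with values here, no step between measured compounds shows what this change does. The change is therefore expected to leave the number near where compound 3 stands, with a step of no change at the digits printed from compound 3 to compound 4 (within the scatter) that stays within the scatter in either direction. For compound 4 the estimate in this assay is 10000 nM, within a range from 4000 nM to 25000 nM.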

Compound 4, half-maximal inhibitory concentration: 10000 nM
Compound 4: middle estimate and measured number agree at the digits printed, within the range that was stated.
By their numbers in this assay, from the lowest: compounds 2, 3 and 4 (each within the scatter of the next).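

In this assay, the exchange of benzyloxy to hydroxy on the aromatic ring gives no change at the digits printed from compound 3 to compound 4 (within the scatter), so a whole six-membered aromatic ring leaves this oxygen with no visible effect on the number. The step of a 1.8-fold higher number from compound 2 to compound 4 (0.25 log units; within the scatter), with 4-hydroxy-2,3-dimethoxyphenyl in place of 2,4-dimethoxyphenyl, also stays within the scatter, and these three substituted benzyl groups are not separated here. No supporting measurement bears on this result. Going by these compounds, whether an amine or a carboxylic acid carried on this oxygen would leave the number where it stands remains open. So does the effect of a longer chain there.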